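The source may hold more compounds than are shown below. What is called first, only, known or untested is meant among the compounds shown, and "the series" means these compounds.

Of the compounds shown here, two have been measured in a functional assay on Jurkat cells (Homo sapiens) for antiproliferative activity, read by MTT assay, with a stated time of 72 h (on this read-out lower numbers stand for stronger inhibition and higher numbers for weaker inhibition), so far. Compound 1, `CN(Cc1ccc(Oc2ccccc2)cc1)Cc1cn(C)c2ccc(CNc3ccc(F)cc3)cc12`, gives 35700 nM in this assay. Compound 2, `CN1CCN(Cc2cn(C)c3ccc(C(=O)Nc4ccc(F)cc4)cc23)CC1`, reaches only the limit of the assay in this assay, recorded as > 100000 nM; this is a boundary of what the assay can report, not a number. Compound 2 therefore stands at the weak end of the two results shown, and the limit of > 100000 nM in this assay, at which 1 of the 2 values shown sits, marks how one of the two values sits at that boundary.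

Compound 3, `Cn1cc(CN2CCN(Cc3ccc(-c4ccccc4)cc3)CC2)c2cc(C(=O)Nc3ccc(F)cc3)ccc21`, has not been measured yet. It differs from compound 2 by 4-phenylphenyl in place of hydrogen on a saturated chain carbon bound to an amine nitrogen in a ring. For the measured compounds named here, no measured pair in this set follows that same change, so the size of the step can only be estimated. Compound 1, `CN(Cc1ccc(Oc2ccccc2)cc1)Cc1cn(C)c2ccc(CNc3ccc(F)cc3)cc12`, carries an extended aromatic group on its chain nitrogen and gives a reportable value of 35700 nM. Compound 2, by contrast, sits at the boundary of what the assay can report. The expectation is therefore that compound 3 moves toward stronger inhibition, meaning a lower number, and is likely to give a reportable value. The step from compound 2 to compound 3 is expected to be an at least 3.3-fold lower number from compound 2 to compound 3 (0.52 log units; beyond the scatter). Compound 3 is thus estimated at 30000 nM in this assay, within a range from 8000 nM to 100000 nM.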

Compound 3, half-maximal inhibitory concentration: > 100000 nM
Compound 3 was reported as a limit (the forecaster's own chance of this, stated with the estimate: 35%); middle value at least 3.3-fold (0.52 log units) away from the limit.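

Compound 2 and compound 3 are both reported only as limits in this assay, not as numbers, so no step between them can be read: the limit of > 100000 nM in this assay, at which 2 of the 3 values shown sit.

The compounds shown leave open whether the 4-phenylphenyl that compound 3 carries in place of hydrogen changes the inhibition at all, and if so, by how much.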